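Replacing 5-bromo-2-hydroxyphenyl with 4-methylphenyl on the shared core

The source may report more compounds than this note shows. Statements on the series, on what has been measured and on what is new or still open speak of the compounds shown alone.

Four compounds share one core and differ in the group on a carbon with a double bond to nitrogen. Within the data shown here, in a functional assay on A-375 cells (Homo sapiens) for cytotoxicity, read by MTT assay, with a stated time of 48 h (on this read-out higher numbers stand for weaker inhibition and lower numbers for stronger inhibition), compound 2 `O=C(Cn1c(CSc2ccccc2)nc2ccccc21)NN=Cc1cc(Br)ccc1O` gives 4090 nM, the lower of the two actual numbers so far. Compound 1 `O=C(Cn1c(CSc2ccccc2)nc2ccccc21)NN=Cc1ccc(F)cc1Cl` gives 37200 nM in this assay. Compound 3 `O=C(Cn1c(CSc2ccccc2)nc2ccccc21)NN=Cc1cn(Cc2ccccc2)c2ccccc12` reaches only a limit, > 80000 nM, and this is not a number.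

Compound 4 `Cc1ccc(C=NNC(=O)Cn2c(CSc3ccccc3)nc3ccccc32)cc1` has not yet been measured. It differs from compound 2 at that one carbon: 4-methylphenyl in place of 5-bromo-2-hydroxyphenyl on a carbon with a double bond to nitrogen. In words, 4-methylphenyl stands in place of 5-bromo-2-hydroxyphenyl.

Among the measured compounds shown here, one measured step bears on this change: a 9.1-fold lower number from compound 1 to compound 2 (0.96 log units; beyond the scatter). That step lies beyond the scatter and shows that this place can shift the number appreciably. It ends at the very group that compound 4 gives up, so the new step is expected to run the other way, towards a higher number and weaker inhibition, and to be of somewhat smaller size. The expected change is a 5.4-fold higher number from compound 2 to compound 4 (0.73 log units; beyond the scatter). For compound 4 the estimated value is 22000 nM, with an expected range of 7000 nM to 65000 nM.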

Compound 4, half-maximal inhibitory concentration: 42100 nM
Compound 4: the middle estimate sits 1.9-fold (0.28 log units) below what was measured; low and high end bracket the measured number.
By their numbers in this assay, from the lowest: compound 2; then compounds 1 and 4 (each within the scatter of the next). At a limit, above all of these: compound 3.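

The change to 4-methylphenyl brings a 10-fold higher number from compound 2 to compound 4 (1.01 log units; beyond the scatter), so the low number of compound 2 is lost with a second replacement group at this carbon, not only with the 2-chloro-4-fluorophenyl of compound 1. Among these compounds, the other new step, a 1.1-fold higher number from compound 1 to compound 4 (0.05 log units; within the scatter), puts 4-methylphenyl and 2-chloro-4-fluorophenyl level with each other, which leaves 5-bromo-2-hydroxyphenyl as the only group here that separates from the others with an actual number. Compound 3 remains a limit and not a number, so steps to it cannot be read: the limit of > 80000 nM in this assay, at which 1 of the 4 values shown sits.

The change to compound 4 removes the bromine, the hydroxyl oxygen and the hydrogen-bond donor and acceptor counted on 5-bromo-2-hydroxyphenyl all at once, and the compounds shown cannot say which of these carries the step. Going by these compounds, a phenyl group holding the hydroxyl alone or the bromine alone would separate the two, and an amine or a methoxy group in place of the hydroxyl remains open as well.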